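This account rests on a few compounds, and the source may have more. Where it says the series, first, only, none or still open, it means among the compounds named here.

Working notes on the series. Compound 1 `O=C(CCl)Nc1ccc(S(=O)(=O)Oc2ccccc2I)cc1` gives 4100 nM in a functional assay on HT-29 cells (Homo sapiens) for antiproliferative activity, read by sulforhodamine B assay, with a stated time of 48 h; a lower number here means a stronger inhibitor, a higher number a weaker inhibitor. Compound 2 `CCNC(=O)Nc1ccc(S(=O)(=O)Oc2ccccc2I)cc1` gives 5300 nM in this assay; the step of a 1.3-fold higher number from compound 1 to compound 2 (0.11 log units; within the scatter) is the only one measured so far. Compound 2 thus carries the higher of the two numbers, with compound 1 nearest, the gap between them within the scatter.

Compound 3 `O=C(Nc1ccc(S(=O)(=O)Oc2ccccc2I)cc1)NC1CC1` is not yet measured. It differs from compound 2 by cyclopropyl in place of ethyl on an amide-type nitrogen. Among the measured compounds shown here, no measured step touches the substituent on this amide-type nitrogen; the one step available, from compound 1 to compound 2, exchanged the group on the carbonyl carbon and stayed within the scatter. On that basis the exchange of ethyl for cyclopropyl in the (ethylcarbamoyl)amino group is expected to give no step beyond the scatter, so a 1.1-fold lower number from compound 2 to compound 3 (0.03 log units; within the scatter) is the estimate. Compound 3 is therefore expected to give about 5000 nM in this assay, within a range of 2000 nM to 12000 nM.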

Compound 3, half-maximal inhibitory concentration: 14000 nM
Estimate against measurement, compound 3: 2.8-fold (0.45 log units) below; measured number outside the range, above it.
By their numbers in this assay, from the lowest: compounds 1 and 2 (each within the scatter of the next); then compound 3.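

Among the compounds shown here, the substituent on the amide-type nitrogen is the first place where a single exchange goes beyond the scatter: in this assay, cyclopropyl in place of ethyl gives a 2.6-fold higher number from compound 2 to compound 3 (0.42 log units; beyond the scatter) even though both groups are all carbon, with no hydrogen-bond donors or acceptors. Measured against the chloromethyl group on the carbonyl carbon, cyclopropylamino also gives a step beyond the scatter, a 3.4-fold higher number from compound 1 to compound 3 (0.53 log units; beyond the scatter) where ethylamino stayed within it, so this place in the series is not indifferent to its substituent. No available evidence bears on what lies behind this step.

From the compounds shown here alone, only ethyl and cyclopropyl stand on this nitrogen, and it remains open whether the higher number follows the three-membered ring itself or the change from ethyl more generally. A longer chain such as n-butyl, or a larger ring such as cyclohexyl, would help separate these two readings.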